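This account rests on a few compounds, and the source may have more. Where it says the series, first, only, none or still open, it means among the compounds named here.

Measured compounds:
compound 1 `COc1ccccc1NC(=O)Nc1cccc(CNc2ncnc3ccccc23)c1` gives 30800 nM in a functional assay on A549 cells (Homo sapiens) for antiproliferative activity, read by MTT assay; on this read-out lower numbers stand for stronger inhibition and higher numbers for weaker inhibition;
compound 2 `O=C(Nc1ccc(F)cc1)Nc1cccc(CNc2ncnc3ccccc23)c1` gives 21000 nM in this assay.

These two numbers sit within the usual scatter of each other: a 1.5-fold lower number from compound 1 to compound 2 (0.17 log units; within the scatter). Compound 2 therefore cannot be set apart from compound 1 on the numbers shown.

Compound 3 `O=C(Nc1cccc(Cl)c1)Nc1cccc(CNc2ncnc3ccccc23)c1` differs from compound 2 in one place: 3-chlorophenyl in place of 4-fluorophenyl on an amide-type nitrogen. Within the data shown here, the only measured step that touches this part of the molecule is the one from compound 1 to compound 2, where another aryl group on the same amide-type nitrogen was exchanged and the number moved only within the scatter. With no measured step beyond the scatter at this position, no step beyond the scatter is expected in this assay here either. Compound 3 is expected to give about 20000 nM, between 8000 nM and 50000 nM. That estimate amounts to a 1.1-fold lower number from compound 2 to compound 3 (0.02 log units; within the scatter).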

Compound 3, half-maximal inhibitory concentration: > 50000 nM
Compound 3: only a limit was reported; the forecaster's own chance of this, stated with the estimate: 10%; middle value at least 2.5-fold (0.39 log units) away from the limit.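

The step at this amide-type nitrogen now goes beyond the scatter in this assay: the exchange of 4-fluorophenyl for 3-chlorophenyl gives an at least 2.3-fold higher number from compound 2 to compound 3 (0.37 log units; beyond the scatter), so the aryl group here is not interchangeable, as the earlier step of a 1.5-fold lower number from compound 1 to compound 2 (0.17 log units; within the scatter) alone might have suggested. For compound 3 the reported figure is a limit and not a number: the limit of > 50000 nM in this assay, at which 1 of the 3 values shown sits. Against the 2-methoxyphenyl group the reading is weaker, with an at least 1.6-fold higher number from compound 1 to compound 3 (0.21 log units; that floor lies within the scatter), so compound 3 cannot be set apart from compound 1 on the numbers shown.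

The compounds shown leave open how far compound 3 lies past its limit, and whether the step follows from the chlorine or from where it sits on the ring. Going by these compounds, how an unsubstituted phenyl group or a carboxylic acid on the aryl ring would read here also remains open.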